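Urea series on DU-145 cells: trifluoromethyl to chloro step

The source may report more compounds than this note shows. Statements on the series, on what has been measured and on what is new or still open speak of the compounds shown alone.

Compound 1, `O=C(Nc1cccc(-n2cc(-c3ccncc3)c(-c3cc(O)cc(Cl)c3)n2)c1)Nc1ccc(Cl)c(C(F)(F)F)c1`, in a functional assay on DU-145 cells (Homo sapiens) for inhibition, read by sulforhodamine B assay, with a stated time of 48 h, tested at 10 uM (a lower number here means a stronger effect, a higher number a weaker effect of the compound at the concentration tested), gives 18.7%.
Compound 2, `O=C(Nc1cccc(-n2cc(-c3ccncc3)c(-c3cc(O)cc(Cl)c3)n2)c1)Nc1ccc(Cl)c(Cl)c1`, in this assay gives -15.1%.
Compound 3, `COc1cc(Cl)cc(-c2nn(-c3cccc(NC(=O)Nc4ccc(Cl)c(C(F)(F)F)c4)c3)cc2-c2ccncc2)c1`, in this assay gives 15.2%.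

The change chloro in place of trifluoromethyl on an aromatic carbon gives a number 33.8 percentage points lower from compound 1 to compound 2 (beyond the scatter). The cores of compound 1 and compound 3 differ by methyl in place of hydrogen on an oxygen on an aromatic ring, and that change gives a number 3.5 percentage points lower from compound 1 to compound 3 (within the scatter), so the two cores behave alike in this assay as far as three compounds show.

Compound 4, `COc1cc(Cl)cc(-c2nn(-c3cccc(NC(=O)Nc4ccc(Cl)c(Cl)c4)c3)cc2-c2ccncc2)c1`, differs from compound 3 by chloro in place of trifluoromethyl on an aromatic carbon; the place of the change is worded the same as for the pair compound 1 and compound 2, so it is the same change on the other core.

For compound 4 the step is expected to be a number 30.2 percentage points lower from compound 3 to compound 4 (beyond the scatter), resting on the step of a number 33.8 percentage points lower from compound 1 to compound 2 (beyond the scatter) and on the near-equal values of compound 1 and compound 3.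

Compound 4 is therefore estimated at -15% in this assay, between -35% and 5%.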

Compound 4, a percentage reported as activity, at one concentration (the size of the read-out at that concentration, not a potency): 12.1%
Compound 4: middle estimate off by 27.1 percentage points, on the low side, and the stated range ends below it.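

In this assay the change from trifluoromethyl to chloro gives a number 3.1 percentage points lower from compound 3 to compound 4 (within the scatter), so the step seen on the core of compound 1 does not carry over to the core of compound 3: the same change on two cores in this assay, a number 33.8 percentage points lower (beyond the scatter) from compound 1 to compound 2 and a number 3.1 percentage points lower (within the scatter) from compound 3 to compound 4, 30.7 percentage points apart, beyond the scatter of two such steps

Read the other way, methyl in place of hydrogen on the oxygen gives a number 27.2 percentage points higher from compound 2 to compound 4 (beyond the scatter), so the two cores match with the 4-chloro-3-(trifluoromethyl)phenyl group but not with the 3,4-dichlorophenyl group: the same change on two cores in this assay, a number 3.5 percentage points lower (within the scatter) from compound 1 to compound 3 and a number 27.2 percentage points higher (beyond the scatter) from compound 2 to compound 4, 30.7 percentage points apart, beyond the scatter of two such steps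

The two changes therefore do not add up across these four compounds, but this does not show why, nor whether compound 2, at -15.1%, is a lone exception or part of a wider pattern.

Still open, as far as these compounds go, is how a bromo or nitrile group in place of trifluoromethyl would behave on each core. Also open, from the compounds shown here alone, is whether an ethoxy group or an amine in place of the hydroxyl would follow compound 2 or compound 4.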